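A Larger Branch on the Saturated Ring of Compound 3

The compounds below may be only part of what the source reports. "The series", "measured", "known", "first", "only" and "open" are said of these compounds alone.

Compound 3 `CCNC(=O)c1cnc(N2CCN(C3CCN(Cc4ccc(Cl)cc4)CC3)[C@@H](C)C2)c(Cl)c1` gives 2.3 nM in a functional assay for antagonist activity at C-X-C chemokine receptor type 3 (Homo sapiens) (on this read-out higher numbers stand for weaker inhibition and lower numbers for stronger inhibition), the lowest of the three numbers. Compound 1 `C[C@H]1CN(c2ncc(C(=O)NCc3ccc(F)c(F)c3)cc2Cl)CCN1C1CCN(Cc2ccc(Cl)cc2)CC1` gives 6 nM, and compound 2 `CC(=O)Nc1cnc(N2CCN(C3CCN(Cc4ccc(Cl)cc4)CC3)[C@@H](C)C2)c(Cl)c1` gives 8 nM. The steps of a 2.6-fold lower number from compound 1 to compound 3 (0.42 log units; beyond the scatter) and a 3.5-fold lower number from compound 2 to compound 3 (0.54 log units; beyond the scatter) lie beyond the scatter, while a 1.3-fold higher number from compound 1 to compound 2 (0.12 log units; within the scatter) does not. Compound 4 `CCNC(=O)c1cnc(N2CCN(C3CCN(Cc4ccc(Cl)cc4)CC3)[C@@H](C(C)C)C2)c(Cl)c1` differs from compound 3 by isopropyl in place of methyl on a saturated ring carbon. For the measured compounds named here, none of the measured steps touches this saturated ring carbon; each of them changes the group on an aromatic carbon or the amide substituent. No direct guide exists, so for compound 4 a step of a 1.7-fold higher number from compound 3 to compound 4 (0.24 log units; within the scatter) within the scatter is expected in this assay. Compound 4 is estimated at 4 nM, with a range from 1.5 nM to 12 nM.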

Compound 4, half-maximal inhibitory concentration: 23 nM
For compound 4 the middle estimate is 5.8-fold (0.76 log units) below the measured one; the measured number lies above the stated range.
By their numbers in this assay, from the lowest: compound 3; then compounds 1 and 2 (each within the scatter of the next); then compound 4.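

On this saturated ring carbon, next to the ring nitrogen, the branch matters: isopropyl in place of methyl gives a 10-fold higher number from compound 3 to compound 4 (1.00 log units; beyond the scatter) in this assay, a step well beyond the scatter. For the compounds shown here, the earlier steps changed only the group on an aromatic carbon or the amide substituent, so this is the first reading at this position, and it is larger than any of them. Nothing measured here explains this step. The compounds shown leave open what ethyl or hydroxymethyl on this carbon would give. They also leave open whether the same change would cost as much with the acetamido group of compound 2.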